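Replacing the 4-ethylphenyl group of compound 3

The source may hold more compounds than are shown below. What is called first, only, known or untested is meant among the compounds shown, and "the series" means these compounds.

Measured in a functional assay on Fem-X cells (Homo sapiens) for cytotoxicity, read by MTT assay, with a stated time of 72 h; on this read-out higher numbers stand for weaker inhibition and lower numbers for stronger inhibition
Compound 1 `COc1ccc(Nc2cc(-c3cccc(C(F)(F)F)c3)ccn2)cc1` gives 68000 nM
Compound 2 `CCc1ccc(Nc2nc3ccccc3cc2-c2ccccc2)cc1` gives 92000 nM
Compound 3 `CCc1ccc(Nc2cc(-c3cccc(C(F)(F)F)c3)ccn2)cc1` gives > 200000 nM

For compound 3 the reading > 200000 nM is a limit and not a number. Compound 4 `COc1cccc(Nc2cc(-c3cccc(C(F)(F)F)c3)ccn2)c1` differs from it by 3-methoxyphenyl in place of 4-ethylphenyl on a nitrogen on an aromatic ring and has 3-methoxyphenyl in place of 4-ethylphenyl on a nitrogen on an aromatic ring. Within the data shown here, the one measured step that bears on this is an at least 2.9-fold higher number from compound 1 to compound 3 (0.46 log units; beyond the scatter) and it put ethyl in place of methoxy on an aromatic carbon. Taking that step backwards suggests a lower number in this assay for compound 4, although no measured compound carries the 3-methoxyphenyl group. The expected size is an estimated at least 2.5-fold lower number from compound 3 to compound 4 (0.39 log units; beyond the scatter) and it stays uncertain. For compound 4 the expected value is 80000 nM and the estimated range runs from 30000 nM to 200000 nM in this assay.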

Compound 4, half-maximal inhibitory concentration: > 200000 nM
Compound 4: only a limit was reported (the forecaster's own chance of this, stated with the estimate: 20%); at least 2.5-fold (0.39 log units) between middle value and limit.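

In this assay, 3-methoxyphenyl in place of 4-methoxyphenyl on the nitrogen gives an at least 2.9-fold higher number from compound 1 to compound 4 (0.46 log units; beyond the scatter). In this pair, then, having a methoxy group on that ring does not by itself preserve the lower number of compound 1; where the group sits also matters. The step between compound 3 and compound 4 cannot be read, because both readings are limits: the limit of > 200000 nM in this assay, at which 2 of the 4 values shown sit.

Still open, as far as these compounds go, is whether an amine or a carboxylic acid on this phenyl ring would give a number below that limit in this assay.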